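Swapping Dibromomethyl for Methyl at a Ring Carbon

A few compounds are considered here, and "the series" means these few. Any claim that something is new, unique, unknown or untested is made for them only; others in the source may bear on it.

Compound 1 `CCC[C@@H](OC(C)=O)C1=C(Br)[C@@](C)(OC)OC1=O`: 2.8 ug/mL
Compound 2 `CCC[C@@H](OC(C)=O)C1=C(Br)[C@@](OC)(C(Br)Br)OC1=O`: 6.2 ug/mL
Compound 3 `CCC[C@@H](OC(C)=O)C1=C(Br)[C@](OC)(C(Br)Br)OC1=O`: 6.1 ug/mL

In a functional assay on KB cells (Homo sapiens) for cytotoxicity (a higher number here means that more compound is needed for the effect, a lower number that less compound is needed), compound 2 gives a number that compound 3 matches within the scatter, while compound 1 gives a lower number, beyond the scatter. Compound 4 `CCC[C@@H](OC(C)=O)C1=C(Br)[C@](C)(OC)OC1=O` is compound 2 with methyl in place of dibromomethyl on a saturated ring carbon. Within the data shown here, two measured steps bear on this. The step of a 2.2-fold higher number from compound 1 to compound 3 (0.34 log units; beyond the scatter) is the same change run backwards, so undoing it should lower the number by a similar amount. The step of a 1.0-fold lower number from compound 2 to compound 3 (0.01 log units; within the scatter) shows that the drawn configuration at that carbon matters little, which rests on (the fact that compounds 2 and 3 differ only in the configuration as drawn). A modest fall in this assay is therefore expected, about the size of the step between compound 1 and compound 3; the estimated step is a 2.1-fold lower number from compound 2 to compound 4 (0.33 log units; beyond the scatter). Compound 4 is thus expected at 2.9 ug/mL, within 1.5 ug/mL to 5.5 ug/mL.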

Compound 4, concentration for half-maximal effect: 4.7 ug/mL
Estimate against measurement, compound 4: 1.6-fold (0.21 log units) below, and the stated range covers the measured number.
By their numbers in this assay, from the lowest: compounds 1, 4, 3 and 2 (each within the scatter of the next, the first and the last beyond it).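

In this assay, methyl in place of dibromomethyl on this saturated ring carbon gives a 1.3-fold lower number from compound 2 to compound 4 (0.12 log units; within the scatter), so the swap need not move the number beyond the scatter, and its two readings agree: the same change on two cores in this assay, a 2.2-fold higher number (0.34 log units; beyond the scatter) from compound 1 to compound 3 and a 1.3-fold higher number (0.12 log units; within the scatter) from compound 4 to compound 2, 1.7-fold (0.22 log units) apart, within the scatter of two such steps. The drawn configuration at this carbon also makes little measurable difference with methyl, as it did with dibromomethyl, with a 1.7-fold higher number from compound 1 to compound 4 (0.22 log units; within the scatter) as the reading for this pair: the fact that compounds 1 and 4 differ only in the configuration as drawn.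

Only methyl and dibromomethyl are shown at this carbon. From the compounds shown here alone, whether a longer chain or an amine there would shift the number clearly remains open.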